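Swapping the amide substituent on a sulfonamide core

This account rests on a few compounds, and the source may have more. Where it says the series, first, only, none or still open, it means among the compounds named here.

Compound 1 `O=C(O)c1cccc(S(=O)(=O)N2CCC(NS(=O)(=O)c3cc(S(=O)(=O)c4ccccc4)ccc3C(F)(F)F)CC2)c1` gives 190 nM in an assay on U2OS cells for inhibition of secreted frizzled-related protein 1 (Homo sapiens), read by a luciferase reporter, with a stated time of 18 h; on this read-out lower numbers stand for an effect already at smaller amounts and higher numbers for an effect only at larger amounts of compound.
Compound 2 `O=C(O)c1ccc(N2CCC(NS(=O)(=O)c3cc(S(=O)(=O)c4ccccc4)ccc3C(F)(F)F)CC2)cc1` gives 230 nM in this assay.
Compound 3 `CC(C)(C)OC(=O)N1CC[C@@H](C(=O)N2CCC(NS(=O)(=O)c3cc(S(=O)(=O)c4ccccc4)ccc3C(F)(F)F)CC2)C1` gives 80 nM in this assay.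

Compound 3 shows the lowest number of the three. Compound 1 sits nearest to it with a higher number, and compound 2 furthest with a higher number still; both of these gaps fall beyond the usual scatter. Compound 4 `O=C(CC1CCNCC1)N1CCC(NS(=O)(=O)c2cc(S(=O)(=O)c3ccccc3)ccc2C(F)(F)F)CC1` keeps the shared core of compound 3 and changes only one part: (piperidin-4-yl)methyl in place of 1-(tert-butoxycarbonyl)pyrrolidin-3-yl on a carbonyl carbon.

Within the data shown here, only one measured step is available, a 1.2-fold higher number from compound 1 to compound 2 (0.08 log units; within the scatter). That step concerns a group on an amine nitrogen in a ring, not the carbonyl carbon altered here, so it does not bear directly on the present change. It does show that exchanging one substituent for another on this core can leave the number within the scatter. Among the measured compounds shown here, no measured pair reports the result of replacing a tert-butoxycarbonyl-bearing five-membered ring by a free six-membered ring with a hydrogen-bond donor, so the direction remains open. A modest step is therefore expected in this assay, with a wide range: the expected step is a 1.9-fold higher number from compound 3 to compound 4 (0.27 log units; within the scatter). Compound 4 is estimated at 150 nM, between 40 nM and 550 nM.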

Compound 4, half-maximal effective concentration: 210 nM
Compound 4: middle estimate off by 1.4-fold (0.15 log units), on the low side; the measured number falls inside the stated range.
By their numbers in this assay, from the lowest: compound 3; then compounds 1, 4 and 2 (each within the scatter of the next).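

On the carbonyl carbon, in this assay, (piperidin-4-yl)methyl in place of 1-(tert-butoxycarbonyl)pyrrolidin-3-yl gives a 2.6-fold higher number from compound 3 to compound 4 (0.42 log units; beyond the scatter), a step beyond the scatter, so the group at this position does affect the number. Groups of quite different make-up on the ring nitrogen of the shared core can still give matching numbers, with a 1.1-fold lower number from compound 2 to compound 4 (0.04 log units; within the scatter) and a 1.1-fold higher number from compound 1 to compound 4 (0.04 log units; within the scatter), both within the scatter, so a carboxyphenyl group is not required for a number in this range. No available data explain the step from the tert-butoxycarbonyl compound to the piperidine compound.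

As far as these compounds go, this single change alters the ring size, the tert-butoxycarbonyl group and the hydrogen-bond donor count together, so the part responsible remains open. A pyrrolidin-3-yl group with a free ring amine would help separate these parts.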